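This account rests on a few compounds, and the source may have more. Where it says the series, first, only, none or still open, it means among the compounds named here.

Values in a functional assay on BV-2 cells (Mus musculus) for inhibition, read by Griess assay, with stated times of 3 h and 24 h (a higher number here means a weaker inhibitor, a lower number a stronger inhibitor), for the measured compounds:

compound 1 `O=S(=O)(/C=C/c1ccc(O)c(O)c1)NCc1ccc(C(F)(F)F)cc1` — 12600 nM
compound 2 `O=S(=O)(/C=C/c1ccc(O)c(O)c1)NCc1ccc(F)cc1` — 18900 nM
compound 3 `Cc1ccc(CNS(=O)(=O)/C=C/c2ccc(O)c(O)c2)cc1` — 43900 nM

Compound 3 stands at the highest number of the three, that is, as the weakest inhibitor shown: the steps of a 3.5-fold higher number from compound 1 to compound 3 (0.54 log units; beyond the scatter) and a 2.3-fold higher number from compound 2 to compound 3 (0.37 log units; beyond the scatter) both lie beyond the scatter, whereas the step of a 1.5-fold higher number from compound 1 to compound 2 (0.18 log units; within the scatter) does not.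

Compound 4 `COc1ccc(CNS(=O)(=O)/C=C/c2ccc(O)c(O)c2)cc1` differs from compound 3 by methoxy in place of methyl on an aromatic carbon. Going by the values given here, no measured step exchanges methyl for methoxy, so none bears directly on this change. The two steps that end at compound 3 show only that methyl gave a weaker inhibitor than trifluoromethyl or fluoro on the same ring; they give no direction for methoxy. In this assay, therefore, no step beyond the scatter is expected from compound 3 to compound 4. The expected step is a 1.3-fold lower number from compound 3 to compound 4 (0.10 log units; within the scatter). Compound 4 is estimated at 35000 nM, with a range from 15000 nM to 80000 nM.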

Compound 4, half-maximal inhibitory concentration: 26500 nM
Beside the measured number, compound 4's estimate is 1.3-fold (0.12 log units) above it; the measured number falls inside the stated range.
By their numbers in this assay, from the lowest: compounds 1, 2, 4 and 3 (each within the scatter of the next, the first and the last beyond it).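

In this assay, the step from methyl to methoxy at this carbon, para to a large group, adds a hydrogen-bond acceptor yet gives only a 1.7-fold lower number from compound 3 to compound 4 (0.22 log units; within the scatter), and the exchange of fluoro for methoxy is no clearer, at a 1.4-fold higher number from compound 2 to compound 4 (0.15 log units; within the scatter). Trifluoromethyl alone stays apart from methoxy, with a 2.1-fold higher number from compound 1 to compound 4 (0.32 log units; beyond the scatter), so compound 1 now differs beyond the scatter from both compound 3 and compound 4, while compound 2 does so only from compound 3. No available evidence bears on the reason for these differences.

The compounds shown leave open how a hydroxyl, an amine or a carboxylic acid at this carbon would read, and whether a longer chain than methoxy would stay within the scatter of compound 4. They also leave open whether these steps hold when the shared core is changed elsewhere.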